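Butenolide diterpenoids: ring hydroxylation and nitric oxide inhibition

A few compounds are considered here, and "the series" means these few. Any claim that something is new, unique, unknown or untested is made for them only; others in the source may bear on it.

Compound 1 `C=C1CC[C@@H]2[C@](C)(CO)[C@H](O)CC[C@@]2(C)[C@@H]1CCC1=CCOC1=O` gives 21000 nM in a functional assay on RAW264.7 cells (Mus musculus) for inhibition, read by Griess assay, with a stated time of 24 h; a lower number here means a stronger inhibitor, a higher number a weaker inhibitor. Compound 2 `C=C1[C@@H](CCC2=CCOC2=O)[C@]2(C)CC[C@@H](O)[C@@](C)(CO)[C@H]2C[C@@H]1O` differs from compound 1 by hydroxy in place of hydrogen on a saturated ring carbon. Compound 2 reaches only a limit of this assay, > 100000 nM. The step of an at least 4.7-fold higher number from compound 1 to compound 2 (0.67 log units; beyond the scatter) is therefore bounded by the limit of > 100000 nM in this assay, at which 1 of the 3 values shown sits. Compound 3 `C=C1CC[C@H]2[C@@](C)(CCC(=O)[C@@]2(C)CO)[C@@H]1CCC1=CCOC1=O` gives 10100 nM in this assay; how its core differs from that of compound 1 is not broken down here.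

Compound 4 `C=C1CC[C@H]2[C@@](C)(C[C@H](O)C(=O)[C@@]2(C)CO)[C@@H]1CCC1=CCOC1=O` differs from compound 3 by hydroxy in place of hydrogen on a saturated ring carbon. This is the same kind of change as from compound 1 to compound 2, but the surroundings differ: there the ring carried a group of 8 heavy atoms and a methyl on a three-bond ring atom, here a hydroxymethyl and two methyl groups on two-bond ring atoms. Resting on the weakening seen in compound 2, a step of a 4.5-fold higher number from compound 3 to compound 4 (0.65 log units; beyond the scatter) is expected, and compound 4 is estimated at 45000 nM, between 15000 nM and 150000 nM.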

Compound 4, half-maximal inhibitory concentration: 12200 nM
Compound 4: the middle estimate sits 3.7-fold (0.57 log units) above what was measured; the measured number lies below the stated range.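

Hydroxy in place of hydrogen on a saturated ring carbon gives a 1.2-fold higher number from compound 3 to compound 4 (0.08 log units; within the scatter) in this assay. The change therefore does not carry over at one size between these two cores: the same change on two cores in this assay, an at least 4.7-fold higher number (0.67 log units; beyond the scatter) from compound 1 to compound 2 and a 1.2-fold higher number (0.08 log units; within the scatter) from compound 3 to compound 4, at least 3.9-fold (0.59 log units) apart, beyond the scatter of two such steps

What sets the two steps apart is not shown, and the full size of the earlier step stays open, as compound 2 gives only a limit and not a number: the limit of > 100000 nM in this assay, at which 1 of the 4 values shown sits.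

Going by these compounds, whether an amine or a methoxy group on these ring carbons would behave as hydroxy does on either core remains open. So does the size of the hydroxy step on any further core.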